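Removing the methoxy from the aryl group on the amide nitrogen

The source may hold more compounds than are shown below. What is called first, only, known or untested is meant among the compounds shown, and "the series" means these compounds.

Compound 1, `COc1ncc(-c2ccc3c(c2)N(C2CCCCC2)C(=O)CO3)cc1NS(=O)(=O)c1ccc(F)cc1`, in a functional assay on HCT-116 cells (Homo sapiens) for antiproliferative activity, read by MTT assay, with a stated time of 72 h (a lower number here means a stronger inhibitor, a higher number a weaker inhibitor), is reported only as a limit, > 40000 nM.
Compound 2, `COc1cccc(N2C(=O)COc3ccc(-c4cnc(OC)c(NS(=O)(=O)c5ccc(F)cc5)c4)cc32)c1`, in this assay is likewise reported only as a limit, > 40000 nM.

Both measured values sit at the same place, (the limit of > 40000 nM in this assay, at which 2 of the 2 values shown sit), so neither compound shows a number of its own. Among the compounds with values here, the one step between them, a step that the two limits leave unreadable from compound 1 to compound 2, is therefore unreadable, and compound 2 stands only at a limit with no ranking against compound 1.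

Compound 3, `COc1ncc(-c2ccc3c(c2)N(c2ccccc2)C(=O)CO3)cc1NS(=O)(=O)c1ccc(F)cc1`, differs from compound 2 by hydrogen in place of methoxy on an aromatic carbon. Within the data shown here, no measured step bears on this change: the only step recorded, a step that the two limits leave unreadable from compound 1 to compound 2, cannot be read in either direction, and nothing else among the measured compounds varies at this place. Among the measured compounds shown here, with no step to lean on, the expectation for compound 3 rests on compound 2 alone, which gives only > 40000 nM, and so compound 3 is expected to remain at or near that limit, with the step of a number no higher from compound 2 to compound 3 (the limit leaves the size open) expected to be small or not readable. The estimate for compound 3 in this assay is 40000 nM, within a range from 8000 nM to 200000 nM.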

Compound 3, half-maximal inhibitory concentration: 18800 nM
Compound 3: middle estimate off by 2.1-fold (0.33 log units), on the high side, and the stated range covers the measured number.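

In this assay, within the data shown here, compound 3 is the only one of the three compounds with a number of its own, 18800 nM, so the group on the amide nitrogen now shows a readable effect, which the earlier pair could not show. Taking the methoxy off the 3-methoxyphenyl group gives an at least 2.1-fold lower number from compound 2 to compound 3 (0.32 log units; beyond the scatter), and phenyl in place of cyclohexyl gives an at least 2.1-fold lower number from compound 1 to compound 3 (0.32 log units; beyond the scatter), so on this nitrogen the plain phenyl group stands apart from both the 3-methoxyphenyl group and the cyclohexyl group. Both steps give only a lower bound on the change, as the other two compounds stand at a limit of the assay and not at a number: the limit of > 40000 nM in this assay, at which 2 of the 3 values shown sit.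

From the compounds shown here alone, the true size of both steps stays open, and so does whether the cyclohexyl group or the methoxy counts for more in holding the values of the other two compounds at that limit. Also open, going by these compounds, is how a fluorine or a hydroxyl group on the phenyl ring, or a methyl or ethyl group in place of that ring on the amide nitrogen, would compare with compound 3.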